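The source may hold more compounds than are shown below. What is called first, only, known or untested is meant among the compounds shown, and "the series" means these compounds.

Notes on the series. Compound 1 `CCCCCCCCCCCCCCCCCCNC(=O)[C@H]1CSC(CCCCCCCCCCCC)N1` in a functional assay on TSU-Pr1 cells for antiproliferative activity against TSU (Homo sapiens), read by sulforhodamine B assay (a higher number here means a weaker inhibitor, a lower number a stronger inhibitor), gives 10700 nM. Among the compounds with values here, compound 3 `CCCCCCCCCCCCCCCCCCNC(=O)[C@H]1CSC(Cc2ccccc2)N1` in this assay gives 11200 nM, the highest of the two numbers measured so far; the nearest is compound 1, with a 1.0-fold higher number from compound 1 to compound 3 (0.02 log units; within the scatter). For compound 2 `CCCCCCCCCCCCCCCCCCNC(=O)[C@H]1CSC(C2CCCCC2)N1` this assay reports only a limit, > 20000 nM. The steps of an at least 1.8-fold higher number from compound 1 to compound 2 (0.27 log units; that floor lies within the scatter) and an at least 1.7-fold lower number from compound 2 to compound 3 (0.25 log units; that floor lies within the scatter) thus rest on that floor the limit of > 20000 nM in this assay, at which 1 of the 3 values shown sits, and are not full numbers.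

Compound 4 `CCCCCCCCCCCCCCCCCCNC(=O)[C@H]1CSC(c2c[nH]c3ccccc23)N1` is not yet measured. The change from compound 3 is 1H-indol-3-yl in place of benzyl on a saturated ring carbon. The measured steps that bear on it are the other exchanges on the saturated ring carbon of the shared core: an at least 1.7-fold lower number from compound 2 to compound 3 (0.25 log units; that floor lies within the scatter), an at least 1.8-fold higher number from compound 1 to compound 2 (0.27 log units; that floor lies within the scatter) and a 1.0-fold higher number from compound 1 to compound 3 (0.02 log units; within the scatter), none of which reaches beyond the scatter. Within the data shown here, with every exchange at that position so far leaving the number roughly where it was, no step beyond the scatter is expected in this assay, a 1.0-fold lower number from compound 3 to compound 4 (0.01 log units; within the scatter), with some chance of another limit. Compound 4 is expected at 11000 nM, between 4500 nM and 25000 nM.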

Compound 4, half-maximal inhibitory concentration: 4400 nM
Compound 4: the middle estimate sits 2.5-fold (0.40 log units) above what was measured; the whole stated range lies above it.
By their numbers in this assay, from the lowest: compound 4; then compounds 1 and 3 (each within the scatter of the next). At a limit, above all of these: compound 2.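

In this assay the saturated ring carbon of the shared core now gives steps beyond the scatter, a 2.5-fold lower number from compound 3 to compound 4 (0.41 log units; beyond the scatter) and a 2.4-fold lower number from compound 1 to compound 4 (0.39 log units; beyond the scatter), whereas no earlier exchange at this position went beyond it. Compared with benzyl, 1H-indol-3-yl brings a five-membered aromatic ring with 1 hetero atom and 1 hydrogen-bond donor, so this position does respond to at least one exchange of aromatic group. The step of an at least 4.5-fold lower number from compound 2 to compound 4 (0.65 log units; beyond the scatter) is a floor and not a full number, as compound 2 has only a limit: the limit of > 20000 nM in this assay, at which 1 of the 4 values shown sits.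

The compounds shown do not tell whether the step goes with the hydrogen-bond donor or with the second aromatic ring. A naphthyl group or a 1-methyl-1H-indol-3-yl group on the same carbon would separate the two.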